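The source may report more compounds than this note shows. Statements on the series, on what has been measured and on what is new or still open speak of the compounds shown alone.

Measured so far:
Compound 1 `Cc1cc(Nc2cc(-c3ccccc3)[nH]n2)n2ncnc2n1` — in a functional assay on MCF7 cells (Homo sapiens) for inhibition, read by MTT assay, with a stated time of 72 h (a lower number here means a stronger inhibitor, a higher number a weaker inhibitor), compound 1 reaches only the assay limit, > 50000 nM.
Compound 2 `Cc1cc(Nc2cc(-c3ccccc3)[nH]n2)n2nc(SCc3ccc(F)cc3)nc2n1` — compound 2 gives 4020 nM.
Compound 3 `Cc1cc(Nc2cc(-c3ccccc3)[nH]n2)n2nc(SCc3ccc(C(F)(F)F)cc3)nc2n1` — compound 3 gives 4820 nM.

Compound 3 holds the higher of the two numbers measured, with compound 2 as the nearest, the pair separated by a 1.2-fold higher number from compound 2 to compound 3 (0.08 log units; within the scatter). For the measured compounds named here, the one large step in the set is an at least 12-fold lower number from compound 1 to compound 2 (1.09 log units; beyond the scatter), the shared core gaining (4-fluorobenzyl)sulfanyl in place of hydrogen on an aromatic carbon; that value for compound 1 is a limit, so the true size of that step is unknown beyond the bound (the limit of > 50000 nM in this assay, at which 1 of the 3 values shown sits).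

Compound 4 `CCCSc1nc2nc(C)cc(Nc3cc(-c4ccccc4)[nH]n3)n2n1` differs from compound 3 at the chain bound to the sulfur: ethyl in place of 4-(trifluoromethyl)phenyl on a saturated chain carbon bound to a sulfur — the same difference cut one bond further out reads 4-(trifluoromethyl)benzyl to propyl. The step of a 1.2-fold higher number from compound 2 to compound 3 (0.08 log units; within the scatter) shows that exchanging the substituent on that ring changes little; removing the ring altogether is a larger change, not bracketed by any measured pair, and only an at least 12-fold lower number from compound 1 to compound 2 (1.09 log units; beyond the scatter) speaks to the weight of the whole arm. A modest rise in number is expected for compound 4, with wide uncertainty: a 1.9-fold higher number from compound 3 to compound 4 (0.27 log units; within the scatter), so compound 4 is estimated at 9000 nM, between 3000 nM and 30000 nM.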

Compound 4, half-maximal inhibitory concentration: > 50000 nM
Compound 4 was reported as a limit; the forecaster's own chance of this, stated with the estimate: 10%; middle value at least 5.5-fold (0.74 log units) away from the limit.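

With ethyl in place of the aromatic ring on a saturated chain carbon bound to a sulfur, this assay gives an at least 10-fold higher number from compound 3 to compound 4 (1.01 log units; beyond the scatter), and with ethyl in place of 4-fluorophenyl it gives an at least 12-fold higher number from compound 2 to compound 4 (1.09 log units; beyond the scatter); the sulfur-linked propyl arm therefore does not retain the lower numbers seen with the two substituted benzyl arms. The value of compound 4 is a limit, so both steps are bounds and not sizes: the limit of > 50000 nM in this assay, at which 2 of the 4 values shown sit. The step from compound 1 to compound 4 cannot be read, since both of its ends are limits.

Still open, on these data alone, is whether the aromatic ring itself or only the length of the arm matters; a cyclohexylmethyl arm or a longer chain such as hexyl on the sulfur would separate the two. Also open, as far as these compounds go, is how an amine or a carboxylic acid on the benzyl ring would read in this assay.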